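Alkyl chain on the amide nitrogen: the butyl step

This account rests on a few compounds, and the source may have more. Where it says the series, first, only, none or still open, it means among the compounds named here.

Compound 1 `COc1cc2c(cc1OC)C(CC(N)=O)CC2` carries a primary amide on the shared core. In a functional assay on the whole organism (strain Wistar) for inhibition, with Rattus norvegicus as the target, read by paw edema, with stated times of 60 min and 24 h, at a dose of 100 mg/kg by the oral route (a higher number here means more inhibition at the dose given (going by the name of the read-out), a lower number less inhibition), compound 1 gives 26.7%. Compound 2 `CCNC(=O)CC1CCc2cc(OC)c(OC)cc21` gives 33.3% and compound 3 `CCCNC(=O)CC1CCc2cc(OC)c(OC)cc21` gives 26.7%. The numbers of compound 1 and compound 3 are the lower pair of the three, yet all three sit within the scatter of one another: the step of a number 6.6 percentage points higher from compound 1 to compound 2 (within the scatter) and the step of no change at the digits printed from compound 1 to compound 3 (within the scatter) are both within the scatter, and so is a number 6.6 percentage points lower from compound 2 to compound 3 (within the scatter).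

Compound 4 `CCCCNC(=O)CC1CCc2cc(OC)c(OC)cc21` lengthens the chain by one more carbon: butyl in place of hydrogen on an amide-type nitrogen. For the measured compounds named here, the steps that bear on this change are a number 6.6 percentage points higher from compound 1 to compound 2 (within the scatter) and no change at the digits printed from compound 1 to compound 3 (within the scatter), neither of which moved this assay beyond the scatter, and the data contain no measured step in which a longer chain did so. The expected step for compound 4 is therefore a number 1.3 percentage points higher from compound 1 to compound 4 (within the scatter), none beyond the scatter. Compound 4 is estimated at 28%, with a range from 17% to 40%.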

Compound 4, a percentage reported as inhibition, in the whole organism at one dose (the size of the read-out at that dose, not a potency): 36.7%
For compound 4 the middle estimate is 8.7 percentage points below the measured one; low and high end bracket the measured number.
By their numbers in this assay, from the lowest: compounds 1, 3, 2 and 4 (each within the scatter of the next).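

In this assay butyl on the amide-type nitrogen gives a number 10 percentage points higher from compound 1 to compound 4 (within the scatter) and a number 10 percentage points higher from compound 3 to compound 4 (within the scatter) and also a number 3.4 percentage points higher from compound 2 to compound 4 (within the scatter) and so adds a further chain length without any step leaving the scatter. Hydrogen, ethyl, propyl and butyl at this position therefore cannot be told apart in this read-out, and no trend with chain length can be drawn from compound 1, compound 2, compound 3 and compound 4. Nothing at hand explains these numbers.

From the compounds shown here alone, whether a chain longer than butyl, a branched chain such as isopropyl or a ring-bearing group such as benzyl on this nitrogen would move the number beyond the scatter remains open. Also open, going by these compounds, is what a second alkyl group on the same nitrogen, or a carboxylic acid in place of the amide, would do.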